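Moving the phenol hydroxyl in a cytotoxic aryl series

The source may hold more compounds than are shown below. What is called first, only, known or untested is meant among the compounds shown, and "the series" means these compounds.

Compound 1 `Oc1cccc(-c2cc(-c3cccs3)cc(-c3ccccc3O)n2)c1` and compound 2 `Oc1ccc(-c2cc(-c3cccs3)cc(-c3ccccc3O)n2)cc1` share a core bearing a thiophen-2-yl group and a 2-hydroxyphenyl group; compound 3 `Oc1ccc(-c2cc(-c3ccsc3)cc(-c3cccc(O)c3)n2)cc1` and the as yet unmeasured compound 4 `Oc1ccc(-c2cc(-c3ccsc3)cc(-c3ccc(O)cc3)n2)cc1` instead bear a thiophen-3-yl group and a 4-hydroxyphenyl group. How the core of compound 3 differs from that of compound 1 is not broken down here. In a functional assay on DU-145 cells (Homo sapiens) for cytotoxicity, read by CCK-8 assay (a higher number here means a weaker inhibitor, a lower number a stronger inhibitor), compound 1 gives 9300 nM. Compound 2 reaches only a limit, > 50000 nM in this assay, which is a limit and not a number (the limit of > 50000 nM in this assay, at which 1 of the 3 values shown sits). The change 4-hydroxyphenyl in place of 3-hydroxyphenyl on an aromatic carbon thus produced an at least 5.3-fold higher number from compound 1 to compound 2 (0.73 log units; beyond the scatter). Compound 3 gives 2230 nM in this assay. The change to compound 4 is 4-hydroxyphenyl in place of 3-hydroxyphenyl on an aromatic carbon, the same kind of change as from compound 1 to compound 2, though here the place is meta to a 4-hydroxyphenyl group and meta to a thiophen-3-yl group rather than meta to a 2-hydroxyphenyl group and a thiophen-2-yl group. That earlier change gave an at least 5.3-fold higher number from compound 1 to compound 2 (0.73 log units; beyond the scatter). On that basis the expected step is a 4.0-fold higher number from compound 3 to compound 4 (0.61 log units; beyond the scatter). Compound 4 is estimated at 9000 nM in this assay, with a likely range from 3000 nM to 45000 nM.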

Compound 4, half-maximal inhibitory concentration: 2060 nM
Estimate against measurement, compound 4: 4.4-fold (0.64 log units) above; measured number outside the range, below it.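

On the core of compound 3, the same change gave a 1.1-fold lower number from compound 3 to compound 4 (0.03 log units; within the scatter) in this assay, so the step seen on the core of compound 1 did not carry over in size: the same change on two cores in this assay, an at least 5.3-fold higher number (0.73 log units; beyond the scatter) from compound 1 to compound 2 and a 1.1-fold lower number (0.03 log units; within the scatter) from compound 3 to compound 4, at least 5.8-fold (0.76 log units) apart, beyond the scatter of two such steps. Compound 2 stands at > 50000 nM, which is a limit and not a number. With only these two cores, which differ in more than one place, the pairs do not show whether the thiophen-3-yl group, the 4-hydroxyphenyl group or the two together separate the outcomes, nor how the change would behave on any further core.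

The compounds shown leave open whether the outcome on each core depends on the free hydroxyl itself, which a methoxy group or an amine in its place could test. They also leave open how the 2-hydroxyphenyl group and the thiophen-2-yl group would each behave if exchanged singly between the two cores.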